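The compounds below may be only part of what the source reports. "The series", "measured", "known", "first", "only" and "open" are said of these compounds alone.

In a functional assay on HT-29 cells (Homo sapiens) for inhibition, read by MTT assay, with a stated time of 48 h (on this read-out lower numbers stand for stronger inhibition and higher numbers for weaker inhibition), compound 1 `COc1ccc(C/N=C2\NC(=O)/C(=C3\CCNC(=O)c4[nH]ccc43)S2)cc1` gives 11500 nM. Compound 2 `O=C1N/C(=N\Cc2ccc(Cl)cc2)S/C1=C1/CCNC(=O)c2[nH]ccc21` gives > 100000 nM, which is a limit of the assay and not a number. Compound 3 `O=C1N/C(=N\Cc2cccc(Cl)c2)S/C1=C1/CCNC(=O)c2[nH]ccc21` keeps the chloro group but moves it: 3-chlorophenyl in place of 4-chlorophenyl on a saturated chain carbon bound to a double-bonded nitrogen. Going by the values given here, the one measured step, an at least 8.6-fold higher number from compound 1 to compound 2 (0.93 log units; beyond the scatter), puts chloro in place of methoxy on an aromatic carbon, so it offers little guide to moving the chloro group. Only a modest shift towards lower numbers is therefore expected. The expected change is an at least 1.6-fold lower number from compound 2 to compound 3 (0.22 log units; that floor lies within the scatter). Compound 3 is estimated at 60000 nM, with an expected range of 20000 nM to 100000 nM.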

Compound 3, half-maximal inhibitory concentration: 35300 nM
The estimate for compound 3 lay 1.7-fold (0.23 log units) above the measured number; low and high end bracket the measured number.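

In this assay, moving the chloro group alone changes the result, with 3-chlorophenyl in place of 4-chlorophenyl giving an at least 2.8-fold lower number from compound 2 to compound 3 (0.45 log units; beyond the scatter). Even so, 3-chlorophenyl does not match 4-methoxyphenyl at this place, giving a 3.1-fold higher number from compound 1 to compound 3 (0.49 log units; beyond the scatter). The value of compound 2 is a limit of the assay and not a number: the limit of > 100000 nM in this assay, at which 1 of the 3 values shown sits.

Going by these compounds, what 3-methoxyphenyl would give remains open, so it is unknown whether moving the methoxy group would shift the number as moving the chloro group does. Unsubstituted phenyl and a longer chain in place of the benzyl group also remain open.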